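Series notes: carbonyl substituent on the piperidine nitrogen

This account rests on a few compounds, and the source may have more. Where it says the series, first, only, none or still open, it means among the compounds named here.

Measured compounds:
compound 1 `Cc1nc(S(C)(=O)=O)ccc1Oc1ncnc(OC2CCN(C(=O)SC3CC3)CC2)c1F` — 126 nM in a functional assay on isolated protein for inhibition of Glucose-dependent insulinotropic receptor (Rattus norvegicus), read by HTRF and cAMP accumulation; on this read-out lower numbers stand for an effect already at smaller amounts and higher numbers for an effect only at larger amounts of compound
compound 2 `Cc1nc(S(C)(=O)=O)ccc1Oc1ncnc(OC2CCN(C(=O)SC3(C)CC3)CC2)c1F` — 166 nM in this assay

Compound 2 stands highest of the two numbers, and its nearest neighbour is compound 1; the step of a 1.3-fold higher number from compound 1 to compound 2 (0.12 log units; within the scatter) is within the scatter, so the two are not distinguishable here.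

Compound 3 `Cc1nc(S(C)(=O)=O)ccc1Oc1ncnc(OC2CCN(C(=O)C3(F)CCC3)CC2)c1F` differs from compound 2 by a group of 5 heavy atoms (4 carbon, 1 fluorine; one four-membered non-aromatic ring of carbon only) in place of a group of 5 heavy atoms (4 carbon, 1 sulfur; one three-membered non-aromatic ring of carbon only), on a carbonyl carbon. Going by the values given here, no measured step touches this kind of exchange: the only step in hand is the methyl addition from compound 1 to compound 2, which sits at the same region and left the number within the scatter. That is weak support only; a change of the whole group attached to the carbonyl carbon could move the number either way. With nothing pointing in a direction, the expected step of a 1.0-fold lower number from compound 2 to compound 3 (0.02 log units; within the scatter) is none beyond the scatter. Compound 3 is therefore estimated at 160 nM, with a range from 60 nM to 450 nM.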

Compound 3, half-maximal effective concentration: 123 nM
For compound 3 the middle estimate is 1.3-fold (0.11 log units) above the measured one; the measured number falls inside the stated range.
By their numbers in this assay, from the lowest: compounds 3, 1 and 2 (each within the scatter of the next).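

On the carbonyl carbon whose other neighbour is the amide-type nitrogen in a ring, replacing the whole sulfur-containing group with the fluorine-bearing four-membered carbon ring group gives, in this assay, two steps that cannot be told from the scatter: a 1.3-fold lower number from compound 2 to compound 3 (0.13 log units; within the scatter) and a 1.0-fold lower number from compound 1 to compound 3 (0.01 log units; within the scatter). Sulfur in this group is therefore not needed for a number in this range, and the series tolerates a larger exchange here than the methyl addition alone could show. Nothing available explains why the number holds across this exchange.

As far as these compounds go, whether an amine, a carboxylic acid or a longer alkyl chain on the carbonyl carbon would keep the number in this range stays open. So does the separate contribution of the fluorine and of the four-membered ring, which enter together in compound 3.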